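A few compounds are considered here, and "the series" means these few. Any claim that something is new, unique, unknown or untested is made for them only; others in the source may bear on it.

Compounds measured in a functional assay on NCI-H322M cells (Homo sapiens) for cytotoxicity, read by sulforhodamine B assay, with a stated time of 48 h, tested at 10 uM; on this read-out lower numbers stand for a stronger effect and higher numbers for a weaker effect at the one concentration tested: compound 3 `COc1ccc(-c2cc(/C=C/C(=O)c3ccc(N)cc3)[nH]n2)cc1OC` with 24%; compound 1 `COc1cc(-c2cc(/C=C/C(=O)c3ccc(N)cc3)[nH]n2)cc(OC)c1OC` with -32%; compound 2 `COc1ccc(C(=O)/C=C/c2cc(-c3cc(OC)c(OC)c(OC)c3)n[nH]2)cc1OC` with -96%.

From compound 3 to compound 1 the change is methoxy in place of hydrogen on an aromatic carbon, and it gave a number 56 percentage points lower from compound 3 to compound 1 (beyond the scatter). Between compound 1 and compound 2 the change is 3,4-dimethoxyphenyl in place of 4-aminophenyl on a carbonyl carbon, and it gave a number 64 percentage points lower from compound 1 to compound 2 (beyond the scatter). The difference between the core of compound 2 and that of compound 3 is not broken down here. Compound 4 `COc1cc(C(=O)/C=C/c2cc(-c3cc(OC)c(OC)c(OC)c3)n[nH]2)cc(OC)c1OC` has not yet been measured; relative to compound 2 it carries methoxy in place of hydrogen on an aromatic carbon. The place is described in the same words as before, so this is the same change. For compound 4 the expected step is a number 1 percentage points lower from compound 2 to compound 4 (within the scatter), small beside the earlier one, because compound 2 with -96% already sits near the lowest numbers this read-out can give. Compound 4 is estimated at -97%, between -100% and -85%.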

Compound 4, a percentage reported as activity, at one concentration (the size of the read-out at that concentration, not a potency): -41%
Compound 4: middle estimate off by 56 percentage points, on the low side, and the stated range ends below it.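

In this assay the same methoxy in place of hydrogen on an aromatic carbon gave a number 55 percentage points higher from compound 2 to compound 4 (beyond the scatter) and did not repeat the earlier step on the other core. This does not show which feature of the two cores sets the direction, and two pairs of compounds give no rule for a third core. The two steps point in opposite directions, and the gap between them is larger than repeated measurements would explain: the same change on two cores in this assay, a number 56 percentage points lower (beyond the scatter) from compound 3 to compound 1 and a number 55 percentage points higher (beyond the scatter) from compound 2 to compound 4, 111 percentage points apart, beyond the scatter of two such steps

Still open, from the compounds shown here alone, is whether a different group at this place, such as an ethoxy group, a hydroxyl group or a fluorine atom, would also act differently on the two cores. The compounds shown also leave open how the methoxy change would behave on any further core.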